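Removing the catechol hydroxyls from a cytotoxic compound

A few compounds are considered here, and "the series" means these few. Any claim that something is new, unique, unknown or untested is made for them only; others in the source may bear on it.

In a functional assay on DLD-1 cells (Homo sapiens) for cytotoxicity, read by MTT assay; a higher number here means a weaker inhibitor, a lower number a stronger inhibitor:
- compound 1 `CCOc1cc(/C=C/C(=O)C(=Cc2ccc(O)c(OC)c2)C(=O)/C=C/c2ccc(O)c(OCC)c2)ccc1O`: 9630 nM
- compound 2 `CCOc1cc(/C=C/C(=O)C(=Cc2ccc(O)c(O)c2)C(=O)/C=C/c2ccc(O)c(OCC)c2)ccc1O`: 5100 nM

Only these two values are at hand, and compound 2 stands level with compound 1 within the scatter. Among the compounds with values here, the one measured step is a 1.9-fold lower number from compound 1 to compound 2 (0.28 log units; within the scatter), with hydrogen in place of methyl on an oxygen on an aromatic ring.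

The next structure is compound 3 `CCOc1cc(/C=C/C(=O)C(=Cc2ccccc2)C(=O)/C=C/c2ccc(O)c(OCC)c2)ccc1O`. It carries phenyl in place of 3,4-dihydroxyphenyl on a double-bonded chain carbon bound to a double-bonded chain carbon.

Within the data shown here, the measured step touches the same aromatic group, so it is the only guide, and a limited one. Among the measured compounds shown here, no measured compound shows that group without its oxygen substituents. Since the one edit made there stayed within the scatter, no step beyond the scatter is expected in this assay, and no direction can be firmly expected. The estimate amounts to a 1.2-fold higher number from compound 2 to compound 3 (0.07 log units; within the scatter). The range is kept wide for that reason. For compound 3 the estimated value is 6000 nM, with an expected range from 2000 nM to 18000 nM.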

Compound 3, half-maximal inhibitory concentration: 5060 nM
Estimate against measurement, compound 3: 1.2-fold (0.07 log units) above; the measured number falls inside the stated range.
By their numbers in this assay, from the lowest: compounds 3, 2 and 1 (each within the scatter of the next).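

In this assay, exchanging 3,4-dihydroxyphenyl for phenyl on a double-bonded chain carbon bound to a double-bonded chain carbon gives a 1.0-fold lower number from compound 2 to compound 3 (0.00 log units; within the scatter), and exchanging 4-hydroxy-3-methoxyphenyl for phenyl at the same place gives a 1.9-fold lower number from compound 1 to compound 3 (0.28 log units; within the scatter). The earlier pair changed only a methyl on one oxygen, whereas compound 3 has no oxygen substituent on this aromatic ring at all, and it still stands level with both other compounds, so across these three compounds the cytotoxicity read here shows no need for those oxygen substituents. No supporting evidence is available to explain why the read-out stays level across this change.

What the compounds shown leave open is whether this place tolerates any group at all or only these three, since a phenyl carrying an amine or a carboxylic acid, or a pyridine ring in place of the phenyl, could still move the number beyond the scatter. They also leave open whether the two 4-hydroxy-3-ethoxyphenyl groups on the other arms of the shared core matter more to the read-out than the group at this place does.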